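The compounds below may be only part of what the source reports. "The series", "measured", "known", "first", "only" and "open" are said of these compounds alone.

In a functional assay on MCF7 cells (Homo sapiens) for cytotoxicity, read by MTT assay, with a stated time of 72 h (a higher number here means a weaker inhibitor, a lower number a stronger inhibitor), compound 1 (`CCCCN1CCN(CCCCn2c3c(c4ccccc42)C(=O)c2c[n+]([O-])c4ccccc4c2C3=O)CC1`) gives 6900 nM, and compound 2 (`O=C1c2c[n+]([O-])c3ccccc3c2C(=O)c2c1c1ccccc1n2CCCCN1CCCCC1`) gives 150 nM. Compound 2 therefore holds the lower of the two numbers, with a gap beyond the usual scatter. Compound 3 (`CN1CCN(CCCn2c3c(c4ccccc42)C(=O)c2c[n+]([O-])c4ccccc4c2C3=O)CC1`) has not yet been measured in this assay. Its difference from compound 2 is 4-methylpiperazin-1-yl in place of (piperidin-1-yl)methyl on a saturated chain carbon, three bonds along the chain from an aromatic nitrogen: 4-methylpiperazin-1-yl stands in place of (piperidin-1-yl)methyl on a saturated chain carbon, three bonds along the chain from an aromatic nitrogen. For the measured compounds named here, only one measured step bears on this change, a 46-fold lower number from compound 1 to compound 2 (1.66 log units; beyond the scatter), a large step that came with piperidin-1-yl in place of 4-butylpiperazin-1-yl. Compound 3 shares a piperazine ring with compound 1, but it carries methyl rather than butyl and has a shorter chain, and the data do not separate these features. A move toward a higher number is thus expected, though smaller than the measured step. The expected size is a 6.0-fold higher number from compound 2 to compound 3 (0.78 log units; beyond the scatter). Compound 3 is estimated at 900 nM, with an expected range of 200 nM to 4000 nM.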

Compound 3, half-maximal inhibitory concentration: 220 nM
The estimate for compound 3 lay 4.1-fold (0.61 log units) above the measured number; the range from low to high includes it.
By their numbers in this assay, from the lowest: compounds 2 and 3 (each within the scatter of the next); then compound 1.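

In this assay, the change to 4-methylpiperazin-1-yl in place of (piperidin-1-yl)methyl, on a saturated chain carbon, three bonds along the chain from an aromatic nitrogen, amounts to a 1.5-fold higher number from compound 2 to compound 3 (0.17 log units; within the scatter) and so shows that a piperazine ring does not by itself bring the high number of compound 1. The other new comparison, 4-methylpiperazin-1-yl in place of (4-butylpiperazin-1-yl)methyl at the same place, gives a 31-fold lower number from compound 1 to compound 3 (1.50 log units; beyond the scatter) and, taken with a 46-fold lower number from compound 1 to compound 2 (1.66 log units; beyond the scatter) as the earlier step, leaves compound 1, the only one of the three with 4-butylpiperazin-1-yl, apart from the other two. Nothing available gives a measured reason for this separation of compound 1 from compound 2 and compound 3.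

The step from compound 1 to compound 3 changes both the substituent on the piperazine and the chain length, so the compounds shown leave open how much of it belongs to each. They also leave open how the number would respond to a morpholine ring or a dimethylamino group in place of these rings, or to a longer chain such as pentyl linking the ring to the aromatic nitrogen.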